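Swapping dimethylamino for 3-hydroxypyrrolidin-1-yl at a measured limit

The source may hold more compounds than are shown below. What is called first, only, known or untested is meant among the compounds shown, and "the series" means these compounds.

- Compound 1 `Nc1noc2ccc(-n3nc(C(F)(F)F)c4c3C(=O)N(c3ccc(-c5ccccc5CN5CCCC5)cc3F)CC4)cc12` in an ADME assay on a cell-free system (plasma) for protein binding, using equilibrium dialysis: > 98%, a limit and not a number
- Compound 2 `CN(C)Cc1ccccc1-c1ccc(N2CCc3c(C(F)(F)F)nn(-c4ccc5onc(N)c5c4)c3C2=O)c(F)c1` in this assay: > 98%, a limit and not a number

Compound 2 has no exact number in this assay, only its limit of > 98%. Going by the values given here, the one measured step is a step that the two limits leave unreadable from compound 1 to compound 2. All that can be read from it is the limit of > 98% in this assay, at which 2 of the 2 values shown sit.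

Compound 3 `Nc1noc2ccc(-n3nc(C(F)(F)F)c4c3C(=O)N(c3ccc(-c5ccccc5CN5CC[C@@H](O)C5)cc3F)CC4)cc12` keeps the shared core and carries one change, 3-hydroxypyrrolidin-1-yl in place of dimethylamino on a saturated chain carbon bound to an aromatic carbon.

With no readable step to scale from, the expectation starts from the limit of compound 2, > 98%, and stays close to it. The expected move is small and downward: an at least 1.2-fold higher unbound fraction from compound 2 to compound 3 (0.09 log units; that floor lies within the scatter). For compound 3 the estimate is 97.5%, with an expected range from 94.5% to 99%.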

Compound 3, plasma protein binding: > 98%
Compound 3: no number, only a limit (the forecaster's own chance of this, stated with the estimate: 45%); at least 1.2-fold (0.09 log units) (unbound fraction) between middle value and limit.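

No step among compound 1, compound 2 and compound 3 can be read, as each gives only a limit and not a number: the limit of > 98% in this assay, at which 3 of the 3 values shown sit.

The compounds shown leave open whether dimethylamino, pyrrolidin-1-yl and 3-hydroxypyrrolidin-1-yl differ at all in this assay, and by how much.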